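A few compounds are considered here, and "the series" means these few. Any claim that something is new, unique, unknown or untested is made for them only; others in the source may bear on it.

Among the measured compounds shown here, in a functional assay on NCI-H460 cells (Homo sapiens) for positive allosteric modulation, read by MTT assay, with stated times of 2 h and 72 h, tested at 3 uM (on this read-out higher numbers stand for weaker inhibition and lower numbers for stronger inhibition), compound 1 (`COc1ccc(C(=O)Nc2ccccc2-c2nnn(-c3ccc(OC)cc3)n2)cc1`) gives 156 nM and compound 2 (`CCCc1ccc(C(=O)Nc2ccccc2-c2nnn(-c3cccc(OC)c3)n2)cc1`) gives 173 nM, so compound 2 stands within the scatter of the only other measured compound. Compound 3 (`COc1cccc(-n2nnc(-c3ccccc3NC(=O)c3ccc(NC(C)=O)cc3)n2)c1`) carries acetamido in place of propyl on an aromatic carbon, para to a large group: acetamido in place of propyl on an aromatic carbon. For the measured compounds named here, no measured step isolates this change, so only a modest move towards a higher number, meaning weaker inhibition, is expected in this assay. The expected step is a 1.7-fold higher number from compound 2 to compound 3 (0.24 log units; within the scatter). Compound 3 is estimated at 300 nM, with an expected range of 100 nM to 900 nM.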

Compound 3, half-maximal inhibitory concentration: 554 nM
Compound 3: middle estimate off by 1.8-fold (0.27 log units), on the low side; the measured number falls inside the stated range.
By their numbers in this assay, from the lowest: compounds 1 and 2 (each within the scatter of the next); then compound 3.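

In this assay, acetamido in place of propyl on an aromatic carbon, para to a large group, gives a 3.2-fold higher number from compound 2 to compound 3 (0.51 log units; beyond the scatter) and this lies beyond the scatter, towards weaker inhibition. This is the first single-place change shown at this position, and it shows that the position responds to the group it carries. No measurement at hand explains the step. Still open, as far as these compounds go, is how an amine, a carboxylic acid or a longer chain would read at this position. From the compounds shown here alone, whether the step would carry over to the core of compound 1 is also open.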